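Exchanging iodo for methoxy on the shared core

This account rests on a few compounds, and the source may have more. Where it says the series, first, only, none or still open, it means among the compounds named here.

In a functional assay on HT-29 cells (Homo sapiens) for inhibition, read by MTT assay, with a stated time of 72 h (on this read-out higher numbers stand for weaker inhibition and lower numbers for stronger inhibition), compound 1 `COc1cc(/C=C/C(=O)c2ccc3ccccc3c2)cc(Br)c1OC` gives 22800 nM and compound 2 `COc1cc(/C=C/C(=O)c2ccc3ccccc3c2)cc(I)c1OC` gives 13300 nM. These two numbers lie within the usual scatter of each other, so compound 2 holds no real lead over compound 1. The next compound, compound 3 `COc1cc(/C=C/C(=O)c2ccc3ccccc3c2)cc(OC)c1OC`, differs from compound 2 as follows: methoxy in place of iodo on an aromatic carbon. This is methoxy in place of iodo on an aromatic carbon. For the measured compounds named here, only one measured step bears on it: a 1.7-fold lower number from compound 1 to compound 2 (0.23 log units; within the scatter), which is iodo in place of bromo. Going by the values given here, that step stays within the scatter, but it exchanges one halogen for another, and no measured compound carries methoxy at this place. No change beyond the scatter is therefore expected in this assay, and no direction is favoured. The expected step is a 1.1-fold lower number from compound 2 to compound 3 (0.04 log units; within the scatter). For compound 3 the estimated value is 12000 nM, with an expected range of 4500 nM to 32000 nM.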

Compound 3, half-maximal inhibitory concentration: 28100 nM
Compound 3: middle estimate off by 2.3-fold (0.37 log units), on the low side, and the stated range covers the measured number.
By their numbers in this assay, from the lowest: compounds 2, 1 and 3 (each within the scatter of the next, the first and the last beyond it).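

For the compounds shown here, at this place on the shared core, methoxy gives the first step in this assay that clears the scatter, with a 2.1-fold higher number from compound 2 to compound 3 (0.32 log units; beyond the scatter) as a modest loss of inhibition against iodo. Against bromo the same group shows no such separation, with a 1.2-fold higher number from compound 1 to compound 3 (0.09 log units; within the scatter) inside the scatter, so compound 2 stands apart from compound 3 while compound 1 stands apart from neither of them. Nothing measured here gives a reason for these steps.

As far as these compounds go, it remains open whether fluoro, an amine, a carboxylic acid or a longer chain such as ethoxy at this place would read closer to iodo or to methoxy. The compounds shown also leave open whether the modest step from iodo to methoxy holds on any other cell line.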